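A few compounds are considered here, and "the series" means these few. Any claim that something is new, unique, unknown or untested is made for them only; others in the source may bear on it.

Measured in an ADME assay on the whole organism (plasma, strain Balb) for pharmacokinetics, with Mus musculus as the target, at a dose of 10 mg/kg by the intravenous route; on this read-out lower numbers stand for lower exposure and higher numbers for higher exposure at the dose given:
Compound 1 `NC(=O)c1cc(-c2ccnc(N)n2)[nH]c1-c1cc(C(F)(F)F)ccc1Cl`: 10100 ng.h/mL
Compound 2 `CCc1ccc(Cl)cc1-c1[nH]c(-c2ccnc(N)n2)cc1C(N)=O`: 684 ng.h/mL

Among the measured compounds shown here, only these two compounds have been measured in this assay, and no single-place step connects them. Compound 2, at 684 ng.h/mL, holds the lower of the two numbers. Compound 1, at 10100 ng.h/mL, stands well above it, and the gap between them lies beyond the usual scatter.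

The next compound is compound 3 `CCc1ccc(C(F)(F)F)cc1-c1[nH]c(-c2ccnc(N)n2)cc1C(N)=O`. Going from compound 2 to compound 3, trifluoromethyl takes the place of chloro on an aromatic carbon, para to an ethyl group (trifluoromethyl in place of chloro on an aromatic carbon). For the measured compounds named here, no measured step shows what this exchange does on its own, so any forecast remains loose. Going by the values given here, the only guide to direction is the higher number of compound 1 at 10100 ng.h/mL, which leaves room above compound 2 but does not isolate this change. A modest rise is therefore expected, and the estimated change is a 2.2-fold higher number from compound 2 to compound 3 (0.34 log units; beyond the scatter). For compound 3 the expected value is 1500 ng.h/mL, with an estimated range from 400 ng.h/mL to 6000 ng.h/mL.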

Compound 3, area under the concentration-time curve: 7770 ng.h/mL
The estimate for compound 3 lay 5.2-fold (0.71 log units) below the measured number; measured number outside the range, above it.
By their numbers in this assay, from the lowest: compound 2; then compounds 3 and 1 (each within the scatter of the next).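

In this assay, among the compounds shown here, trifluoromethyl in place of chloro on an aromatic carbon, para to an ethyl group, gives an 11-fold higher number from compound 2 to compound 3 (1.06 log units; beyond the scatter) and so provides the first reading of this exchange on its own, a large step well beyond the scatter. With trifluoromethyl held in place, the second exchange, ethyl in place of chloro on an aromatic carbon, gives a 1.3-fold lower number from compound 1 to compound 3 (0.11 log units; within the scatter) and stays within the scatter, so compound 1 and compound 3 cannot be told apart on this read-out, and in this pair the group that changes leaves no readable difference. No measurement of any other kind bears on these two steps, and the data therefore give no account of how the trifluoromethyl exchange acts on exposure.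

The compounds shown leave open whether the large step belongs to trifluoromethyl in particular or would also appear with another group at this place, such as a nitrile, a methoxy group or a methyl group. They also leave open whether the same exchange would give a step of this size with a longer chain, such as a propyl group, in place of the ethyl group.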